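Adding a Hydroxy Group to a Quinoline Acylhydrazone

The source may report more compounds than this note shows. Statements on the series, on what has been measured and on what is new or still open speak of the compounds shown alone.

Measured so far:
Compound 1, `O=C(N/N=C/c1ccc2ccccc2n1)c1ccccc1`: 25000 nM
Compound 2, `NC(=S)N/N=C/c1ccc2ccccc2n1`: 21000 nM

Both numbers come from a functional assay on PC-3 cells (Homo sapiens) for cytotoxicity, read by MTT assay, with a stated time of 72 h; a lower number here means a stronger inhibitor, a higher number a weaker inhibitor. In this assay compound 1 gives 25000 nM, while compound 2, which carries a thiosemicarbazide in place of the benzoylhydrazide, gives 21000 nM. The two values lie within the usual scatter of each other, so compound 1 cannot be told apart from compound 2 on these figures; both are weak inhibitors.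

Compound 3, `O=C(N/N=C/c1ccc2ccccc2n1)c1ccccc1O`, has not yet been measured. It differs from compound 1 in one place: hydroxy in place of hydrogen on an aromatic carbon. For the measured compounds named here, no measured pair in this set isolates such a change, so there is no step to lean on. The expectation is a modest move toward a lower number, of a size that may or may not clear the scatter, giving an expected step of a 2.1-fold lower number from compound 1 to compound 3 (0.32 log units; beyond the scatter) in this assay. The estimate for compound 3 in this assay is 12000 nM, with a likely range from 4000 nM to 35000 nM.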

Compound 3, half-maximal inhibitory concentration: 20000 nM
For compound 3 the middle estimate is 1.7-fold (0.22 log units) below the measured one, within the range that was stated.
By their numbers in this assay, from the lowest: compounds 3, 2 and 1 (each within the scatter of the next).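

In this assay the change from phenyl to 2-hydroxyphenyl gives a 1.3-fold lower number from compound 1 to compound 3 (0.10 log units; within the scatter) and so the two compounds cannot be told apart. For the compounds shown here, this is the first measured pair in the set that differs in one place only, and it shows that a hydroxy ortho to a large group, on this six-membered aromatic ring, leaves no change that can be read on these figures. No measurement at hand bears on why this single added group leaves the value within the scatter.

Going by these compounds, what remains open is whether a different group at this same place, such as an amine, a methoxy or a carboxylic acid, would move the number beyond the scatter. On these data alone, it is also open whether a hydroxy on another aromatic carbon of this ring would behave the same way.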